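Dibromination of the salicylamide in a benzothiazolyl thioether series

A few compounds are considered here, and "the series" means these few. Any claim that something is new, unique, unknown or untested is made for them only; others in the source may bear on it.

Compound 1 `COc1ccccc1C(=O)Nc1ccc(Sc2nc3ccccc3s2)cc1` gives only a limit in an assay for inhibition of HSP60/HSP10 (Homo sapiens), with a stated time of 60 min (on this read-out higher numbers stand for weaker inhibition and lower numbers for stronger inhibition), namely > 100000 nM. Compound 2 `COc1c(Br)cccc1C(=O)Nc1ccc(Sc2nc3ccccc3s2)cc1` likewise reaches only a limit in this assay, > 100000 nM. Compound 3 `O=C(Nc1ccc(Sc2nc3ccccc3s2)cc1)c1cccc(Br)c1O` gives 26000 nM in this assay.

The two cores differ as 3-bromo-2-hydroxyphenyl in place of 2-methoxyphenyl on a carbonyl carbon. Within the core of compound 1, the change bromo in place of hydrogen on an aromatic carbon made a step that the two limits leave unreadable from compound 1 to compound 2, which follows from the limit of > 100000 nM in this assay, at which 2 of the 3 values shown sit. Compound 4 `O=C(Nc1ccc(Sc2nc3ccccc3s2)cc1)c1cc(Br)cc(Br)c1O` carries the same kind of change on the core of compound 3, (bromo in place of hydrogen on an aromatic carbon), but its place differs: here the entering bromo sits meta to a bromo group and para to a hydroxy group, not ortho to a methoxy group. Beside the unreadable earlier step, the step from compound 3 to compound 4 is expected to be a 1.7-fold lower number from compound 3 to compound 4 (0.24 log units; within the scatter), resting on compound 3 alone giving a readable number, 26000 nM. Compound 4 is expected to give about 15000 nM, between 5000 nM and 60000 nM.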

Compound 4, half-maximal inhibitory concentration: 4700 nM
Compound 4: middle estimate off by 3.2-fold (0.50 log units), on the high side, and the stated range ends above it.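

On the core of compound 3, bromo in place of hydrogen on an aromatic carbon gives a 5.5-fold lower number from compound 3 to compound 4 (0.74 log units; beyond the scatter). Changing the whole group on the carbonyl carbon gives an at least 21-fold lower number from compound 2 to compound 4 (1.32 log units; beyond the scatter) and an at least 21-fold lower number from compound 1 to compound 4 (1.32 log units; beyond the scatter). The same bromo change on the core of compound 1 cannot be read, as compound 1 and compound 2 both give only a limit, so a size on one core is shown but not whether it carries over to another: the limit of > 100000 nM in this assay, at which 2 of the 4 values shown sit.

The compounds shown leave open whether chloro, methyl or an amine in place of the entering bromo would read the same in this assay. They also leave open whether the entering bromo would give a readable step with methoxy in place of the hydroxy group.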